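Selenocyanate carbamates: propyl to butyl chain extension

The source may hold more compounds than are shown below. What is called first, only, known or untested is meant among the compounds shown, and "the series" means these compounds.

Measured so far:
compound 1 `CCCOC(=O)Nc1ccc([Se]C#N)cc1`, 51900 nM in a functional assay on HTB-54 cells (Homo sapiens) for cytotoxicity, read by MTT assay, with a stated time of 72 h; a higher number here means a weaker inhibitor of growth, a lower number a stronger inhibitor of growth
compound 2 `O=C(Nc1ccc([Se][Se]c2ccc(NC(=O)OCc3ccccc3)cc2)cc1)OCc1ccccc1`, 50900 nM in this assay

Two compounds have numbers in this assay. Compound 1 gives 51900 nM and compound 2 gives 50900 nM; the two values lie within the usual scatter of each other, so nothing separates them. Among the measured compounds shown here, no step between measured compounds is available for the change at hand.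

Compound 3 `CCCCOC(=O)Nc1ccc([Se]C#N)cc1` is not yet measured. It differs from compound 1 by methyl in place of hydrogen on a saturated chain carbon, three bonds along the chain from an oxygen next to a carbonyl group. Both measured compounds sit at about the same concentration for total growth inhibition, and the change is the smallest chain extension, so no step beyond the scatter is expected in either direction: the expected step of a 1.2-fold lower number from compound 1 to compound 3 (0.06 log units; within the scatter) is small. Compound 3 is estimated at 45000 nM, with a range from 20000 nM to 110000 nM.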

Compound 3, concentration for total growth inhibition: 43400 nM
Estimate against measurement, compound 3: 1.0-fold (0.02 log units) above; the measured number falls inside the stated range.
By their numbers in this assay, from the lowest: compounds 3, 2 and 1 (each within the scatter of the next).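

In this assay, the first step readable at this position is the change from propyl to butyl, which gives a 1.2-fold lower number from compound 1 to compound 3 (0.08 log units; within the scatter). The position therefore tolerates methyl in place of hydrogen on a saturated chain carbon, three bonds along the chain from an oxygen next to a carbonyl group, with no change beyond the scatter, though a single pair sets no trend along the chain. No supporting data bear on this result, so it carries no explanation.

Still open, as far as these compounds go, is whether a longer chain such as hexyl, or a chain ending in an amine or a carboxylic acid, would separate from compound 1 beyond the scatter. Also open, from the compounds shown here alone, is how a diselenide and a selenocyanate compare when they carry the same carbamate.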